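Chloro added beside the trifluoromethyl on the aryl urea

The source may report more compounds than this note shows. Statements on the series, on what has been measured and on what is new or still open speak of the compounds shown alone.

Measured compounds in a functional assay on NCI/ADR-RES cells (Homo sapiens) for inhibition, read by sulforhodamine B assay, with a stated time of 48 h; on this read-out lower numbers stand for stronger inhibition of growth and higher numbers for weaker inhibition of growth:
compound 1 `O=C(Nc1cccc(-n2cc(-c3ccncc3)c(-c3ccc(Cl)c(O)c3)n2)c1)Nc1cccc(C(F)(F)F)c1` gives 2140 nM
compound 2 `O=C(Nc1cccc(-n2cc(-c3ccncc3)c(-c3ccc(Cl)c(O)c3)n2)c1)Nc1cc(C(F)(F)F)cc(C(F)(F)F)c1` gives 1070 nM
compound 3 `COc1cc(-c2nn(-c3cccc(NC(=O)c4ccccc4)c3)cc2-c2ccncc2)ccc1Cl` gives 448 nM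

Compound 1 has the highest number of the three in this assay. Its nearest neighbour is compound 2, reached by the step of a 2.0-fold lower number from compound 1 to compound 2 (0.30 log units; within the scatter), which stays within the scatter. Within the data shown here, compound 3 carries a different amide and a methoxy group rather than a hydroxyl, and no single step to it is set out; its value simply stands furthest from that of compound 1, beyond the scatter.

Compound 4 `O=C(Nc1cccc(-n2cc(-c3ccncc3)c(-c3ccc(Cl)c(O)c3)n2)c1)Nc1ccc(Cl)c(C(F)(F)F)c1` differs from compound 1 by chloro in place of hydrogen on an aromatic carbon. Among the measured compounds shown here, the only step that bears on it is the one to compound 2, where trifluoromethyl in place of hydrogen on the same ring gave a 2.0-fold lower number from compound 1 to compound 2 (0.30 log units; within the scatter), within the scatter. Adding a chloro group on that ring is a change of similar size and is expected to behave much the same way, so no step beyond the scatter is anticipated in this assay.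

Compound 4 is therefore estimated at 1400 nM, with a range of 500 nM to 4000 nM, amounting to an expected step of a 1.5-fold lower number from compound 1 to compound 4 (0.18 log units; within the scatter).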

Compound 4, concentration for 50% growth inhibition: 844 nM
Compound 4: middle estimate off by 1.7-fold (0.22 log units), on the high side; the range from low to high includes it.
By their numbers in this assay, from the lowest: compounds 3, 4, 2 and 1 (each within the scatter of the next, the first and the last beyond it).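

In this assay, chloro in place of hydrogen on the aromatic carbon ortho to the trifluoromethyl group and para to a large group gives a 2.5-fold lower number from compound 1 to compound 4 (0.40 log units; beyond the scatter). Among these compounds, this modest change is the first single-place step from compound 1 to pass beyond the scatter, whereas the earlier step on the same ring, a 2.0-fold lower number from compound 1 to compound 2 (0.30 log units; within the scatter), did not, so the 3-(trifluoromethyl)phenyl group of compound 1 can be improved on by a single added atom. Compound 2 and compound 4 lie within the scatter of each other, so the second trifluoromethyl and the chloro cannot be ranked, and nothing available accounts for the shift seen with chloro.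

The compounds shown leave open whether this shift belongs to chloro itself, since a fluoro, a methyl or an amine on the same carbon might give a similar number or a quite different one. They also leave open whether the chloro would have the same effect without the trifluoromethyl group on that ring, or on a compound with the amide and methoxy group of compound 3.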